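From Pyrrolidinyl to Pyridinyl on the Shared Core

This account rests on a few compounds, and the source may have more. Where it says the series, first, only, none or still open, it means among the compounds named here.

In an assay on CHO cells for inhibition of sodium- and chloride-dependent glycine transporter 1 (Homo sapiens), read by scintillation counting (on this read-out higher numbers stand for an effect only at larger amounts of compound and lower numbers for an effect already at smaller amounts), compound 1 `COc1ccc2c(c1)CN(C(=O)c1cc(S(C)(=O)=O)ccc1O[C@@H](C)C(F)(F)F)C2` gives 180 nM. Compound 2 `C[C@H](Oc1ccc(S(C)(=O)=O)cc1C(=O)N1Cc2ccc(N3CCCC3)cc2C1)C(F)(F)F` carries pyrrolidin-1-yl in place of methoxy on an aromatic carbon, and in this assay compound 2 gives 180 nM. The step of no change at the digits printed from compound 1 to compound 2 (within the scatter) lies within the scatter, so compound 2 stands level with compound 1 on the numbers seen so far. Compound 3 `C[C@H](Oc1ccc(S(C)(=O)=O)cc1C(=O)N1Cc2ccc(-c3ccncc3)cc2C1)C(F)(F)F` differs from compound 2 in one place: pyridin-4-yl in place of pyrrolidin-1-yl on an aromatic carbon. Within the data shown here, only one measured step touches this carbon, and it exchanged methoxy for pyrrolidin-1-yl without any change, so nothing measured speaks directly about pyridin-4-yl there. Because the step of no change at the digits printed from compound 1 to compound 2 (within the scatter) was flat at this position, the expected step is a 1.4-fold higher number from compound 2 to compound 3 (0.14 log units; within the scatter), small and without a direction that rises above the scatter. Compound 3 is therefore estimated at 250 nM in this assay, within a range from 70 nM to 900 nM.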

Compound 3, half-maximal effective concentration: 17 nM
Estimate against measurement, compound 3: 15-fold (1.17 log units) above, outside the stated range (below it).
By their numbers in this assay, from the lowest: compound 3; then compounds 1 and 2 (each within the scatter of the next).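

In this assay this aromatic carbon proves sensitive to what it carries: pyridin-4-yl in place of pyrrolidin-1-yl gives an 11-fold lower number from compound 2 to compound 3 (1.02 log units; beyond the scatter) in the series, and pyridin-4-yl in place of methoxy gives an 11-fold lower number from compound 1 to compound 3 (1.02 log units; beyond the scatter) on the same core. The flat exchange of methoxy for pyrrolidin-1-yl had not revealed this, so the level values of the earlier pair do not mean that the position is indifferent to substitution. No measurement here accounts for the gain.

The compounds shown leave open whether the ring nitrogen of pyridin-4-yl matters, which phenyl or pyridin-3-yl at this carbon would test. They also leave open whether a non-aromatic six-membered ring such as piperidin-4-yl would match pyridin-4-yl there.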